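Methoxy in place of methyl on the sulfonamide aryl group

This account rests on a few compounds, and the source may have more. Where it says the series, first, only, none or still open, it means among the compounds named here.

This account follows a small series built around a shared core, tested in a functional assay on HT-29 cells (Homo sapiens) for antiproliferative activity, read by sulforhodamine B assay, with a stated time of 48 h; a higher number here means a weaker inhibitor, a lower number a stronger inhibitor. Compound 1, `Cc1ccccc1NS(=O)(=O)c1ccc(N2CCNC2=O)cc1`, gives in this assay a value of 200 nM. Among the results shown it is the only actual number; the other reading is a limit of the assay. Compound 2, `CC(C)Cc1ccc(NS(=O)(=O)c2ccc(N3CCNC3=O)cc2)cc1`, gives in this assay only a limit of > 1000 nM, which stands where (the limit of > 1000 nM in this assay, at which 1 of the 2 values shown sits). Compound 3, `COc1cccc(NS(=O)(=O)c2ccc(N3CCNC3=O)cc2)c1`, has not yet been measured. It differs from compound 1 in one place: 3-methoxyphenyl in place of 2-methylphenyl on a sulfonamide nitrogen. Within the data shown here, no measured pair shows a change of this kind, so the size of the step cannot be taken from the data. The author expects a modest loss, with the step of a 2.0-fold higher number from compound 1 to compound 3 (0.30 log units; within the scatter) pointing toward weaker inhibition. Compound 3 is therefore estimated at 400 nM, with a plausible range from 120 nM to 1500 nM.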

Compound 3, half-maximal inhibitory concentration: 120 nM
Compound 3: the middle estimate sits 3.3-fold (0.52 log units) above what was measured; measured number inside the range.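

In this assay, placing 3-methoxyphenyl where 2-methylphenyl stood on a sulfonamide nitrogen gives a 1.7-fold lower number from compound 1 to compound 3 (0.22 log units; within the scatter). Among these compounds, this is the first step that can be read at this position, and it shows that the two groups cannot be told apart here, even though the oxygen-bearing 3-methoxyphenyl differs from 2-methylphenyl in both its substituent and where that substituent sits. Compound 2 gives only a limit, not a number, so no step to it can be read: the limit of > 1000 nM in this assay, at which 1 of the 3 values shown sits.

Among the compounds shown here, the single step changes the substituent and its ring place together, so it cannot show what either change does alone. Going by these compounds, how this position would respond to an aryl group carrying an amine or a carboxylic acid remains open.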